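This account rests on a few compounds, and the source may have more. Where it says the series, first, only, none or still open, it means among the compounds named here.

Of the compounds shown here, three that share one core have been tested in an ADME assay on isolated protein for metabolic stability, with Cocaine esterase (Homo sapiens) as the target; a higher number here means that the compound lasts longer, a lower number that the compound disappears faster. Compound 1 `CCCCOC(=O)[C@@H](N)CCC(=O)NCCSC(=O)c1ccccc1` gives 0.167 h in this assay. Compound 2 `CCCCOC(=O)[C@@H](N)CCC(=O)NCCSC(=O)C(C)(C)C` gives 0.167 h. Compound 3 `CCCOC(=O)[C@@H](N)CCC(=O)NCCSC(C)=O` gives 0.167 h, level with compounds 1 and 2 at the digits shown. Within the data shown here, the single measured step, no change at the digits printed from compound 1 to compound 2 (within the scatter), moved nothing beyond the scatter. Compound 4 `CCCCOC(=O)[C@@H](N)CCC(=O)NCCSC(C)=O` differs from compound 3 by methyl in place of hydrogen on a saturated chain carbon, three bonds along the chain from an oxygen next to a carbonyl group. Among the measured compounds shown here, no measured step touches this part of the molecule; the one step known sat on the carbonyl end and was flat, and all three values agree. Compound 4 is therefore expected to stay at the same level, an estimated step of no change at the digits printed from compound 3 to compound 4 (within the scatter). The estimate for compound 4 is 0.167 h, ranging from 0.1 h to 0.35 h.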

Compound 4, half-life in the Cocaine esterase assay: 0.167 h
Beside the measured number, compound 4's estimate shows no gap at the digits printed; low and high end bracket the measured number.
By their numbers in the Cocaine esterase assay, from the lowest: compounds 1, 2, 3 and 4 (each within the scatter of the next).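

In the Cocaine esterase assay, the propyl to butyl change gives no change at the digits printed from compound 3 to compound 4 (within the scatter), so this position now has a measured step of its own. Methyl on the carbonyl carbon reads the same against the larger groups, with no change at the digits printed from compound 2 to compound 4 (within the scatter) and no change at the digits printed from compound 1 to compound 4 (within the scatter). In a physicochemical assay for lipophilicity, at pH 7.4 (on this read-out higher numbers stand for higher lipophilicity and lower numbers for lower lipophilicity), compound 3 gives -1.21 and compound 4 gives -0.88, and the propyl to butyl change does register as higher lipophilicity: the measured distribution coefficient of compound 3, -1.21, and of compound 4, -0.88, a number 0.33 log units higher (beyond the scatter)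

On these data alone, all four compounds sit at one level in the Cocaine esterase assay, so what would move the half-life remains unknown. As far as these compounds go, whether a longer chain than butyl, or a carboxylic acid in its place, would shift that level stays open.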